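The compounds below may be only part of what the source reports. "The series", "measured", "known", "first", "only" and "open" are said of these compounds alone.

Measured so far in a functional assay on the whole organism with Mus musculus as the target; a higher number here means that more compound is needed for the effect, a lower number that less compound is needed:

Compound 1 `COC(=O)NC1=NC(c2cccc(Cl)c2)CN1` gives 40 mg/kg in this test
Compound 2 `COC(=O)NC1=NC(c2cccc(Br)c2)CN1` gives 28 mg/kg in this test

Among the measured compounds shown here, compound 2, at 28 mg/kg in this assay, has only one neighbour to compare with, and the gap to compound 1 is too small to rank the two. The next compound, compound 3 `COC(=O)NC1=NC(c2cccc(OC)c2)CN1`, keeps the shared core and carries methoxy in place of bromo on an aromatic carbon, meta to a large group. The full count of that change is methoxy in place of bromo on an aromatic carbon and it is the only difference between them.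

For the measured compounds named here, one measured step bears on this change. It is a 1.4-fold lower number from compound 1 to compound 2 (0.15 log units; within the scatter), with bromo in place of chloro on an aromatic carbon. Going by the values given here, that step is small, yet no measurement so far includes a methoxy group, so it offers only weak guidance. The expectation is therefore no change beyond the scatter, with the direction left open, and the estimated step is a 1.4-fold higher number from compound 2 to compound 3 (0.15 log units; within the scatter) here. For compound 3 the estimated dose is 40 mg/kg, with an expected range from 15 mg/kg to 110 mg/kg as its ends.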

Compound 3, dose for half-maximal effect: 58 mg/kg
Compound 3: middle estimate off by 1.5-fold (0.16 log units), on the low side; the measured number falls inside the stated range.
By their numbers in this assay, from the lowest: compounds 2, 1 and 3 (each within the scatter of the next, the first and the last beyond it).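

Methoxy is the first group at this place on the aromatic ring that is not a halogen, and in this assay putting it in place of bromo gives a 2.1-fold higher number from compound 2 to compound 3 (0.32 log units; beyond the scatter) as a modest change that clears the usual scatter. Methoxy in place of chloro gives a 1.5-fold higher number from compound 1 to compound 3 (0.16 log units; within the scatter) and so does not separate compound 3 from compound 1, which means the measurable gap exists only against the bromo compound, compound 2. Methoxy also brings a hydrogen-bond acceptor that neither halogen has, but no supporting measurement shows whether this has any connection with the gap, and none explains the result.

With only bromo, chloro and methoxy at this place, these compounds cannot show whether the numbers in this assay follow any trend across substituents or simply reflect small differences among three groups. A longer chain such as ethoxy, an amine or a hydroxyl at the same place would test whether the step seen with methoxy extends to other groups, and fluoro or iodo would show how far the two halogens' similar numbers carry.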